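This account rests on a few compounds, and the source may have more. Where it says the series, first, only, none or still open, it means among the compounds named here.

Measured so far in a functional assay on A-375 cells (Homo sapiens) for antiproliferative activity, read by trypan blue exclusion, with a stated time of 48 h, tested at 5 uM; a higher number here means a weaker effect of the compound at the concentration tested, a lower number a stronger effect:
- compound 1 `CCCCCCC#Cc1ccc(S(=O)(=O)Nc2cccc(-c3csc(NC(C)=O)n3)c2)cc1` gives 12.8%
- compound 2 `CC(=O)Nc1nc(-c2cccc(NS(=O)(=O)c3ccc(C#CCO)cc3)c2)cs1` gives 99.3%
- compound 3 `CCCCCCCCC#Cc1ccc(S(=O)(=O)Nc2cccc(-c3csc(NC(C)=O)n3)c2)cc1` gives 8.9%

Compound 1 stands second highest of the three numbers. Its nearest neighbour is compound 3, reached by a number 3.9 percentage points lower from compound 1 to compound 3 (within the scatter), a step lying within the scatter; the furthest is compound 2, reached by a number 86.5 percentage points higher from compound 1 to compound 2 (beyond the scatter), a large step. The reverse comparison, a number 90.4 percentage points lower from compound 2 to compound 3 (beyond the scatter), is of the same size in the other direction. What the three numbers show is that the chain on the para side of the sulfonamide phenyl decides the read-out: a long all-carbon chain gives a low number, the hydroxy-bearing short chain a number near the top.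

Compound 4 `CCCCCC/C=C\c1ccc(S(=O)(=O)Nc2cccc(-c3csc(NC(C)=O)n3)c2)cc1` differs from compound 1 as follows: a group of 8 heavy atoms (8 carbon; no ring) in place of a group of 8 heavy atoms (8 carbon; no ring), on an aromatic carbon. For the measured compounds named here, no measured step touches the triple bond itself; the two steps that bear on it concern the chain length and the hydroxy only. The chain length of compound 1 is kept exactly, and no donor or acceptor enters. The expected step of a number 7.2 percentage points higher from compound 1 to compound 4 (within the scatter) is therefore small, with some allowance for the unmeasured change of the triple bond to a double bond. Compound 4 is estimated at 20%, within 8% to 45%.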

Compound 4, a percentage reported as activity, at one concentration (the size of the read-out at that concentration, not a potency): 2.3%
Beside the measured number, compound 4's estimate is 17.7 percentage points above it, outside the stated range (below it).
By their numbers in this assay, from the lowest: compounds 4, 3 and 1 (each within the scatter of the next, the first and the last beyond it); then compound 2.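

In this assay, for the compounds shown here, the triple bond is not needed for a low number at this position: with the count of 8 carbon kept, replacing oct-1-yn-1-yl by the chain with one double bond gives a number 10.5 percentage points lower from compound 1 to compound 4 (beyond the scatter) as a modest step, the first measured change to the multiple bond itself. Set against the chain of 10 carbon, the double-bonded chain gives a number 6.6 percentage points lower from compound 3 to compound 4 (within the scatter) and so cannot be told apart from it, while the step from the short hydroxy-bearing chain is a number 97 percentage points lower from compound 2 to compound 4 (beyond the scatter) and keeps that chain well apart from all three long all-carbon chains. No evidence is available on why the double-bonded chain reads as it does.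

Open at this position are the fully saturated octyl chain, the trans double bond and a chain longer than 10 carbon, which would show whether any multiple bond is needed and how far the chain can grow. Also open, as far as these compounds go, is whether an amine or a carboxylic acid on a long chain behaves like the hydroxy on the short one, and how these single-concentration read-outs translate into potency.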